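A Larger Group on the Ring Nitrogen: Compound 3 Expected

The source may report more compounds than this note shows. Statements on the series, on what has been measured and on what is new or still open speak of the compounds shown alone.

Compound 2 `Nc1scc(CN2CCN(c3ccc(F)cc3F)CC2)c1C(=O)c1ccc(Cl)cc1` gives 0% in a functional assay on CHO cells with adenosine receptor A1 (Homo sapiens) as the target, read by cAMP accumulation and immunoassay, with a stated time of 6 min, tested at 0.01 uM (a lower number here means a stronger effect, a higher number a weaker effect of the compound at the concentration tested), and stands at the low end of the two numbers shown, within the scatter of compound 1 `Nc1scc(CN2CCN(c3ccc(F)cc3Cl)CC2)c1C(=O)c1ccc(Cl)cc1`, which gives 6.1%; the step of a number 6.1 percentage points lower from compound 1 to compound 2 (within the scatter) is within the scatter. Compound 3 `Nc1scc(CN2CCN(CCCc3ccc(Cl)cc3)CC2)c1C(=O)c1ccc(Cl)cc1` differs from compound 2 by 3-(4-chlorophenyl)propyl in place of 2,4-difluorophenyl on an amine nitrogen in a ring. For the measured compounds named here, no measured step covers a change of this kind, and the only measured step, fluoro in place of chloro, was small, so no direction is indicated. Both measured numbers are low, and compound 3 is expected to stay low. For compound 3 the estimate is 3% (from 0% to 15%), which means an expected step of a number 3 percentage points higher from compound 2 to compound 3 (within the scatter).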

Compound 3, a percentage reported as activity, at one concentration (the size of the read-out at that concentration, not a potency): 0%
The estimate for compound 3 lay 3 percentage points above the measured number, and the stated range covers the measured number.
By their numbers in this assay, from the lowest: compounds 2, 3 and 1 (each within the scatter of the next).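

In this assay, 3-(4-chlorophenyl)propyl in place of 2,4-difluorophenyl on the amine nitrogen in a ring gives no change at the digits printed from compound 2 to compound 3 (within the scatter), and in place of 2-chloro-4-fluorophenyl it gives a number 6.1 percentage points lower from compound 1 to compound 3 (within the scatter). This nitrogen therefore carries a propyl chain ending in a chlorophenyl group with a read-out matching those of the directly attached halophenyl groups, a larger change than the earlier halogen swap. Nothing available explains this result.

Still open, on these data alone, is how a shorter chain such as benzyl, or an unsubstituted phenyl, would read here. An amine or carboxylic acid at the end of the propyl chain also remains untested among the compounds shown.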